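The source may hold more compounds than are shown below. What is called first, only, known or untested is meant among the compounds shown, and "the series" means these compounds.

Measured so far:
Compound 1, `C#CCNC1CCc2c(SCCc3ccc(Br)cc3)cccc21`: in an assay on isolated protein for inhibition of Amine oxidase [flavin-containing] B (Homo sapiens) (on this read-out lower numbers stand for stronger inhibition and higher numbers for weaker inhibition), compound 1 gives 85300 nM.
Compound 2, `C#CCNC1CCc2c(SCc3cccc(F)c3)cccc21`: in this assay compound 2 gives 1480 nM.
Compound 3, `C#CCNC1CCc2c(SCCc3cccc(C(F)(F)F)c3)cccc21`: in this assay compound 3 gives 3720 nM.

Among these three numbers compound 3 stands second highest. Compound 2 shows a lower number than compound 3, a gap beyond the usual scatter, and compound 1 shows a markedly higher number than compound 3, again beyond the scatter. Going by the values given here, no single-point steps between measured compounds are available here, so each pair can only be read off its two values.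

The next compound, compound 4, `C#CCNC1CCc2c(SCCc3cccc(Br)c3)cccc21`, differs from compound 3 in one place: bromo in place of trifluoromethyl on an aromatic carbon. Nothing measured here isolates this exchange, so its size cannot be taken from a known step. The account expects that in this assay the change from compound 3 to compound 4 amounts to a 1.1-fold higher number from compound 3 to compound 4 (0.03 log units; within the scatter), a step not clearly beyond the scatter in either direction. Compound 4 is therefore estimated at 4000 nM, with a range from 1000 nM to 15000 nM.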

Compound 4, half-maximal inhibitory concentration: 30500 nM
The estimate for compound 4 lay 7.6-fold (0.88 log units) below the measured number; the measured number lies above the stated range.
By their numbers in this assay, from the lowest: compound 2; then compound 3; then compound 4; then compound 1.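

In this assay the exchange of trifluoromethyl for bromo on this aromatic carbon gives an 8.2-fold higher number from compound 3 to compound 4 (0.91 log units; beyond the scatter) and so shows that, in this pair, the two groups are not interchangeable at this place. The bromo compounds add a second finding: the change to 3-bromophenyl from 4-bromophenyl gives a 2.8-fold lower number from compound 1 to compound 4 (0.45 log units; beyond the scatter) and shows that the place of the bromo on the ring also alters the number. Nothing available here offers an explanation for either step.

On these data alone, whether a chloro, methoxy or nitrile group at the same place would stand nearer to trifluoromethyl or to bromo remains open. As far as these compounds go, it is also open whether 4-trifluoromethylphenyl in place of 3-trifluoromethylphenyl would shift the number in the same direction and by a similar size as the two bromophenyl groups do.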